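This account rests on a few compounds, and the source may have more. Where it says the series, first, only, none or still open, it means among the compounds named here.

Working notes on the series. Compound 1 `COc1cc(-c2cc(/C=C/C(=O)c3ccc(N)cc3)[nH]n2)cc(OC)c1OC` and compound 2 `COc1ccc(-c2cc(/C=C/C(=O)c3ccc(N)cc3)[nH]n2)cc1OC` share one core; compound 3 `COc1cc(C(=O)/C=C/c2cc(-c3cc(OC)c(OC)c(OC)c3)n[nH]2)cc(OC)c1OC` and the still unmeasured compound 4 `COc1ccc(-c2cc(/C=C/C(=O)c3cc(OC)c(OC)c(OC)c3)[nH]n2)cc1OC` share another. The difference between the two cores is not broken down here. In a functional assay on ACHN cells (Homo sapiens) for inhibition, read by sulforhodamine B assay, with a stated time of 48 h (a higher number here means that more compound is tolerated, a lower number that less compound is tolerated), compound 1 gives 8400 nM, and compound 2 gives 6480 nM. The change from compound 1 to compound 2 is hydrogen in place of methoxy on an aromatic carbon, and it made a 1.3-fold lower number from compound 1 to compound 2 (0.11 log units; within the scatter), so the two values are read as equal. In this assay compound 3 gives 5570 nM; against compound 2 and compound 1 it stands within the scatter of both, so no order among the three is claimed. Compound 4 is obtained from compound 3 by hydrogen in place of methoxy on an aromatic carbon, the same change as from compound 1 to compound 2, at the same kind of place. Because the earlier step of a 1.3-fold lower number from compound 1 to compound 2 (0.11 log units; within the scatter) stayed within the scatter, the expectation for compound 4 in this assay is a step of about a 1.2-fold lower number from compound 3 to compound 4 (0.08 log units; within the scatter), again within the scatter, resting on that single earlier instance. The estimate for compound 4 is therefore 4600 nM, expected between 2200 nM and 9500 nM.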

Compound 4, concentration lethal to 50% of the cells: 5500 nM
Compound 4: the middle estimate sits 1.2-fold (0.08 log units) below what was measured; the range from low to high includes it.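

On the core of compound 3, hydrogen in place of methoxy on an aromatic carbon gives a 1.0-fold lower number from compound 3 to compound 4 (0.01 log units; within the scatter) in this assay, so here too the change stays within the scatter. Set beside the earlier step, the change carries from one core to the other with no difference that can be read: the same change on two cores in this assay, a 1.3-fold lower number (0.11 log units; within the scatter) from compound 1 to compound 2 and a 1.0-fold lower number (0.01 log units; within the scatter) from compound 3 to compound 4, 1.3-fold (0.11 log units) apart, within the scatter of two such steps. Within the data shown here, this shows only that the step reads the same on these two cores, at this kind of place; with both steps within the scatter, it does not show that the change has any effect of its own, nor that the agreement would hold on a third core or for a step large enough to be read.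

The compounds shown leave open whether another group at this place, such as a hydroxyl, a chlorine or a longer chain like ethoxy in place of the methoxy, would move the number beyond the scatter. Also open, on these data alone, is whether the two steps would still agree outside this assay.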